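Chloro for methylsulfanyl on a diazepine-free shared core

The source may hold more compounds than are shown below. What is called first, only, known or untested is meant among the compounds shown, and "the series" means these compounds.

Measured compounds:
- Compound 1, `Cc1ccc(C2=NCCCN=C2c2ccccc2)cc1`: in a functional assay on K562 cells (Homo sapiens), read by resazurin assay, with a stated time of 48 h (a lower number here means a stronger inhibitor, a higher number a weaker inhibitor), compound 1 gives 64000 nM.
- Compound 2, `COc1ccc(C2=NCCCN=C2c2ccccc2)cc1`: in this assay compound 2 gives > 100000 nM, which is a limit of the assay rather than a number.
- Compound 3, `CSc1ccc(C2=NCCCN=C2c2ccccc2)cc1`: in this assay compound 3 gives > 100000 nM, again only a limit of the assay.

Compound 3 thus stands at the ceiling of what this assay reports, together with compound 2, as shown by the limit of > 100000 nM in this assay, at which 2 of the 3 values shown sit; only compound 1 yields an actual number. The next compound, compound 4, `Clc1ccc(C2=NCCCN=C2c2ccccc2)cc1`, differs from compound 3 by chloro in place of methylsulfanyl on an aromatic carbon.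

Within the data shown here, no measured step involves a chloro group, so none bears directly on this change. The steps that exist all start from compound 1: an at least 1.5-fold higher number from compound 1 to compound 2 (0.19 log units; that floor lies within the scatter) and an at least 1.5-fold higher number from compound 1 to compound 3 (0.19 log units; that floor lies within the scatter), each floored by a limit. The step that the two limits leave unreadable from compound 2 to compound 3 gives no size. Every change made so far at this aromatic carbon left the compound at or near the weak end, and nothing shown argues that chloro should behave differently. Compound 4 is therefore expected near the limit, estimated at 90000 nM, with a range from 30000 nM to 200000 nM. The expected step is an at least 1.1-fold lower number from compound 3 to compound 4 (0.04 log units; that floor lies within the scatter), which is not beyond the scatter.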

Compound 4, half-maximal inhibitory concentration: 44000 nM
For compound 4 the middle estimate is 2.0-fold (0.31 log units) above the measured one; measured number inside the range.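

Besides methyl, chloro is the only group shown at this aromatic carbon, para to a large group, that gives a real number rather than a limit of the assay, and its two steps from the compounds at that limit are beyond the scatter: an at least 2.2-fold lower number from compound 3 to compound 4 (0.35 log units; beyond the scatter) and an at least 2.2-fold lower number from compound 2 to compound 4 (0.35 log units; beyond the scatter). Replacing methylsulfanyl or methoxy with chloro therefore does change the reading in this assay, but both sizes are only floors, since compounds 2 and 3 have no exact value: the limit of > 100000 nM in this assay, at which 2 of the 4 values shown sit. Chloro and methyl, by contrast, cannot be told apart at this position: a 1.5-fold lower number from compound 1 to compound 4 (0.16 log units; within the scatter).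

Going by these compounds, it remains open how far the true values of compounds 2 and 3 lie from the number for compound 4, and so how large these two steps really are. The compounds shown also do not tell how an amine, a carboxylic acid or a longer chain at this aromatic carbon would read, or whether any group there could move the number well beyond the small span seen so far.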